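The source may report more compounds than this note shows. Statements on the series, on what has been measured and on what is new or still open speak of the compounds shown alone.

Working notes on the series. Compound 1 `Cc1ccc(-c2ccc(F)cc2)n1-c1ccc(-c2nc3ccc(F)cc3s2)cc1` and compound 2 `COc1ccc(-c2ccc(C)n2-c2ccc(-c3nc4ccc(F)cc4s3)cc2)cc1` share one core; compound 3 `COc1cc2nc(-c3ccc(-n4c(C)ccc4-c4ccc(F)cc4)cc3)sc2c(OC)c1OC` and compound 4 `COc1ccc(-c2ccc(C)n2-c2ccc(-c3nc4cc(OC)c(OC)c(OC)c4s3)cc2)cc1` share another, and the difference between the two cores is not broken down here. In an ADME assay on MCF-10A cells (Homo sapiens) for cytotoxicity, read by MTT assay, with a stated time of 72 h (a higher number here means a weaker inhibitor, a lower number a stronger inhibitor), compound 1 gives 37800 nM and compound 2 gives 37800 nM; in this assay compound 3 gives 43200 nM. All three numbers lie within the scatter of one another. The change methoxy in place of fluoro on an aromatic carbon produced a step of no change at the digits printed from compound 1 to compound 2 (within the scatter). The same change, (methoxy in place of fluoro on an aromatic carbon), carries compound 3 to compound 4, on the same kind of position. Going by the values given here, an expected step of a 1.0-fold lower number from compound 3 to compound 4 (0.00 log units; within the scatter) rests on the single measured instance of this change, no change at the digits printed from compound 1 to compound 2 (within the scatter), and on the small spread among all three measured compounds. Compound 4 is therefore expected to give about 43000 nM in this assay, within the range 25000 nM to 75000 nM.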

Compound 4, half-maximal inhibitory concentration: 43900 nM
Compound 4: the middle estimate sits 1.0-fold (0.01 log units) below what was measured; measured number inside the range.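

In this assay, methoxy in place of fluoro gives a step of a 1.0-fold higher number from compound 3 to compound 4 (0.01 log units; within the scatter), and the two instances of the change agree: the same change on two cores in this assay, no change at the digits printed (within the scatter) from compound 1 to compound 2 and a 1.0-fold higher number (0.01 log units; within the scatter) from compound 3 to compound 4, 1.0-fold (0.01 log units) apart, within the scatter of two such steps. On these two cores, then, the change carries over with no measurable effect on the number in either case. This does not show that it would carry to a further core, and two steps that both lie within the scatter cannot show whether a larger effect of some other change would transfer between cores in the same way.

The compounds shown leave open what other groups in place of the fluoro of 4-fluorophenyl, such as an amine or a carboxylic acid, would do. They also leave open whether any single change in this series can move the number in this assay beyond the scatter.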